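Dichloropurine series: dropping one chloro from compound 2

A few compounds are considered here, and "the series" means these few. Any claim that something is new, unique, unknown or untested is made for them only; others in the source may bear on it.

Measured in a functional assay on OVCAR-8 cells (Homo sapiens) for cytotoxicity, read by sulforhodamine B assay, with a stated time of 48 h; a lower number here means a stronger inhibitor of growth, a higher number a weaker inhibitor of growth:
- compound 1 `ClCc1cccc(Cn2cnc3c(Cl)nc(Cl)nc32)c1`: 3540 nM
- compound 2 `ClCc1cccc(Cn2cnc3nc(Cl)nc(Cl)c32)c1`: 21400 nM
- compound 3 `ClCc1ccccc1Cn1cnc2c(Cl)ncnc21`: 5240 nM

Compound 2 gives the highest number of the three; compound 3 lies nearest, compound 1 furthest, both beyond the scatter. Compound 4 `ClCc1cccc(Cn2cnc3ncnc(Cl)c32)c1` has not been run. It differs from compound 2 by hydrogen in place of chloro on an aromatic carbon, the site being between two ring nitrogen atoms. Among the measured compounds shown here, no measured pair shares this change, so only the values guide. Compound 3, carrying a single chloro on its core, gives a lower number than compound 2, and compound 1 a lower one still, so a step toward a lower number is expected for compound 4, of the size a 3.1-fold lower number from compound 2 to compound 4 (0.49 log units; beyond the scatter). Compound 4 is estimated at 7000 nM, with a range of 2500 nM to 20000 nM.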

Compound 4, concentration for total growth inhibition: 14800 nM
Beside the measured number, compound 4's estimate is 2.1-fold (0.33 log units) below it; the measured number falls inside the stated range.
By their numbers in this assay, from the lowest: compounds 1 and 3 (each within the scatter of the next); then compounds 4 and 2 (each within the scatter of the next).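

In this assay, hydrogen in place of chloro on the aromatic carbon between two ring nitrogen atoms gives a 1.4-fold lower number from compound 2 to compound 4 (0.16 log units; within the scatter). Among the compounds shown here, this is the first pair differing in one place, and it shows that this chloro can be removed with no change beyond the scatter. The chloro at this site therefore has no measurable bearing on the read-out for this pair.

Going by these compounds, an amine or a methoxy group at this site remains open, as does the same change on the core of compound 1. No supporting data bear on this result.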